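The source may report more compounds than this note shows. Statements on the series, on what has been measured and on what is new or still open speak of the compounds shown alone.

Measured in a functional assay on HT-29 cells (Homo sapiens) for antiproliferative activity, read by sulforhodamine B assay, with a stated time of 72 h; a lower number here means a stronger inhibitor, a higher number a weaker inhibitor:
- Compound 1 `CCCCCCCCc1ccc(CCC(CO)(CO)NC(=O)CCCCCCC)c2ccccc12`: 22000 nM
- Compound 2 `COc1ccc(CCC(CO)(CO)NC(C)=O)c2ccccc12`: > 80000 nM, a limit of the assay and not a number
- Compound 3 `CCCCCCCOc1ccc(CCC(CO)(CO)NC(=O)CCCCCCC)c2ccccc12`: 18800 nM

Among the measured compounds shown here, compound 3, at 18800 nM, sits within the scatter of compound 1, the only other exact number in the set. The next compound to be tested is compound 4 `C/C=C/C(=O)NC(CO)(CO)CCc1ccc(OCCCCCCC)c2ccccc12`, which has prop-1-en-1-yl in place of heptyl on a carbonyl carbon.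

For the measured compounds named here, the one measured step, a 1.2-fold lower number from compound 1 to compound 3 (0.07 log units; within the scatter), has heptyloxy in place of octyl on an aromatic carbon. It therefore lies elsewhere in the molecule and gives no direct size for this change. Going by the values given here, no step at the carbonyl carbon has been measured.

The expectation leans towards a higher number because the limit of > 80000 nM in this assay, at which 1 of the 3 values shown sits, is reached by compound 2 within this small set. A step of a 1.7-fold higher number from compound 3 to compound 4 (0.23 log units; within the scatter) is expected, with low confidence. For compound 4 the estimated value is 32000 nM, with an expected range of 13000 nM to 80000 nM.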

Compound 4, half-maximal inhibitory concentration: 36400 nM
Beside the measured number, compound 4's estimate is 1.1-fold (0.06 log units) below it, within the range that was stated.
By their numbers in this assay, from the lowest: compounds 3, 1 and 4 (each within the scatter of the next). At a limit, above all of these: compound 2.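

At the carbonyl carbon, the only step shown at this position in this assay is prop-1-en-1-yl in place of heptyl, which gives a 1.9-fold higher number from compound 3 to compound 4 (0.29 log units; within the scatter). Going from 7 heavy atoms to 3 and adding a double bond outside aromatic rings therefore leaves the number within the scatter, so with heptyloxy held constant, these two compounds show no need for the full heptyl chain on the carbonyl carbon. Compound 2 remains the one value that is a limit and not a number, and it differs from compound 4 in more than one place: the limit of > 80000 nM in this assay, at which 1 of the 4 values shown sits.

This step joins a shorter chain with a double bond, so the compounds shown do not separate the two. From the compounds shown here alone, how a saturated propyl chain or a longer chain ending in an amine would read on this carbonyl carbon remains open.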